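Compound 3: one more step at the assay limit

A few compounds are considered here, and "the series" means these few. Any claim that something is new, unique, unknown or untested is made for them only; others in the source may bear on it.

Measured in a functional assay on MCF7 cells (Homo sapiens) for antiproliferative activity, read by MTT assay, with a stated time of 48 h (a higher number here means a weaker inhibitor, a lower number a stronger inhibitor), are two compounds
Compound 1 `CCn1c(C(=O)NCC#N)ccc1C(CC)(CC)c1ccc(OCCC(O)(CC)CC)c(C)c1` gives > 50000 nM as a limit
Compound 2 `C#CC(C)OC(=O)c1ccc(C(CC)(CC)c2ccc(OCCC(O)(CC)CC)c(C)c2)n1CC` gives > 50000 nM as a limit

Compound 2 stands at > 50000 nM in this assay and this is a limit. The picture so far is the limit of > 50000 nM in this assay, at which 2 of the 2 values shown sit, and no number. Compound 3 `CCC(C)C(NC(=O)c1ccc(C(CC)(CC)c2ccc(OCCC(O)(CC)CC)c(C)c2)n1CC)C(=O)O` carries (1-carboxy-2-methylbutyl)amino in place of (1-methylprop-2-yn-1-yl)oxy on a carbonyl carbon and keeps the shared core. Among the measured compounds shown here, the one measured step at this place is a step that the two limits leave unreadable from compound 1 to compound 2 and it offers no size to carry over. With compound 2 at > 50000 nM as the only anchor, no gain beyond the scatter is expected for compound 3 in this assay and another limit is the likeliest report. The estimated change is a number no higher from compound 2 to compound 3 (the limit leaves the size open) in this expectation. Compound 3 is estimated at 50000 nM with an expected range from 20000 nM to 120000 nM in this measurement.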

Compound 3, half-maximal inhibitory concentration: 11300 nM
For compound 3 the middle estimate is 4.4-fold (0.65 log units) above the measured one, and the stated range ends above it.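

In this assay, compound 3 is the first compound shown to give a number rather than a limit: the limit of > 50000 nM in this assay, at which 2 of the 3 values shown sit. At this place on the carbonyl carbon, (1-carboxy-2-methylbutyl)amino in place of (1-methylprop-2-yn-1-yl)oxy gives an at least 4.4-fold lower number from compound 2 to compound 3 (0.64 log units; beyond the scatter), and 1-carboxy-2-methylbutyl in place of cyanomethyl on the amide-type nitrogen gives an at least 4.4-fold lower number from compound 1 to compound 3 (0.64 log units; beyond the scatter); both sizes are lower bounds, set by the limits of the starting compounds. The step between the two limits, from compound 1 to compound 2, cannot be read.

The compounds shown do not tell whether the carboxylic acid or the branched chain of this group carries the step, a question that a methyl ester or a plain alkylamino group on the same carbonyl carbon could address. Going by these compounds, how a shorter or longer chain here would read also remains open.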